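Nitrofuran amides: removing the methoxy from compound 3

The source may hold more compounds than are shown below. What is called first, only, known or untested is meant among the compounds shown, and "the series" means these compounds.

Measured so far in an ADME assay on microsomes from liver (Homo sapiens) for metabolic stability; on this read-out higher numbers stand for fast clearance and lower numbers for slow clearance:
compound 1 `O=C(Nc1ccc(-c2cnc3ccccn23)cc1)c1ccc([N+](=O)[O-])o1` gives 85.1 mL.min-1.g-1
compound 2 `COc1ccn2c(-c3ccc(NC(=O)c4ccc([N+](=O)[O-])o4)cc3)cnc2c1` gives 74.2 mL.min-1.g-1
compound 3 `COc1ccn2c(-c3ccc(NC(=O)c4ccc([N+](=O)[O-])o4)cc3C)cnc2c1` gives 48.8 mL.min-1.g-1

The three values lie within the scatter of one another; compound 3 stands at 48.8 mL.min-1.g-1, against 74.2 mL.min-1.g-1 for compound 2 and 85.1 mL.min-1.g-1 for compound 1. Neither the step of a 1.1-fold lower number from compound 1 to compound 2 (0.06 log units; within the scatter) nor the step of a 1.5-fold lower number from compound 2 to compound 3 (0.18 log units; within the scatter) moves this assay beyond the scatter.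

Compound 4 `Cc1cc(NC(=O)c2ccc([N+](=O)[O-])o2)ccc1-c1cnc2ccccn12` is not yet measured. It differs from compound 3 by hydrogen in place of methoxy on an aromatic carbon. The step that bears directly on it is the reverse of the methoxy addition from compound 1 to compound 2, which was a 1.1-fold lower number from compound 1 to compound 2 (0.06 log units; within the scatter). On that basis the change from compound 3 to compound 4 is expected to leave this assay within the scatter, with no direction beyond it, so the expected step is a 1.1-fold higher number from compound 3 to compound 4 (0.05 log units; within the scatter). Compound 4 is therefore estimated at 55 mL.min-1.g-1, in the range 32 mL.min-1.g-1 to 95 mL.min-1.g-1.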

Compound 4, intrinsic clearance in microsomes: 51 mL.min-1.g-1
Compound 4: the middle estimate sits 1.1-fold (0.03 log units) above what was measured; the range from low to high includes it.
By their numbers in this assay, from the lowest: compounds 3, 4, 2 and 1 (each within the scatter of the next).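

In this assay, hydrogen in place of methoxy on the aromatic carbon opposite the ring nitrogen gives a 1.0-fold higher number from compound 3 to compound 4 (0.02 log units; within the scatter) and so tests the methoxy change on a second core, one that carries the methyl, where it again stays within the scatter: the same change on two cores in this assay, a 1.1-fold lower number (0.06 log units; within the scatter) from compound 1 to compound 2 and a 1.0-fold lower number (0.02 log units; within the scatter) from compound 4 to compound 3, 1.1-fold (0.04 log units) apart, within the scatter of two such steps. The methyl change also now stands on a second core, without the methoxy, with a 1.7-fold lower number from compound 1 to compound 4 (0.22 log units; within the scatter) as its new step: the same change on two cores in this assay, a 1.5-fold lower number (0.18 log units; within the scatter) from compound 2 to compound 3 and a 1.7-fold lower number (0.22 log units; within the scatter) from compound 1 to compound 4, 1.1-fold (0.04 log units) apart, within the scatter of two such steps. Across these four compounds, neither change, alone or with the other, takes this assay beyond the scatter on either core.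

Going by these compounds, whether an amine, a carboxylic acid or a longer chain at the methoxy position would move this assay beyond the scatter remains open. The compounds shown also leave open whether any change away from these two places would do so.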